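The source may report more compounds than this note shows. Statements on the series, on what has been measured and on what is new or still open speak of the compounds shown alone.

For the measured compounds named here, in a functional assay on A549 cells (Homo sapiens) for antiproliferative activity, read by MTT assay, with a stated time of 72 h (on this read-out lower numbers stand for stronger inhibition and higher numbers for weaker inhibition), the two compounds measured so far sit level. Going by the values given here, compound 1 (`O=C(Nc1ccc(Nc2nccc(NC3CCCCC3)n2)cc1)Nc1ccc(Cl)c(C(F)(F)F)c1`) gives 7430 nM and compound 2 (`CCCNc1ccnc(Nc2ccc(NC(=O)Nc3ccc(Cl)c(C(F)(F)F)c3)cc2)n1`) gives 7320 nM, so compound 2 lies within the scatter of its only neighbour. The next structure, compound 3 (`Cn1cc(Nc2ccnc(Nc3ccc(NC(=O)Nc4ccc(Cl)c(C(F)(F)F)c4)cc3)n2)cn1`), keeps the shared core and changes one group: 1-methyl-1H-pyrazol-4-yl in place of propyl on a nitrogen on an aromatic ring. Put simply, 1-methyl-1H-pyrazol-4-yl comes in place of propyl on a nitrogen on an aromatic ring.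

Among the compounds with values here, only one measured step bears on this place: a 1.0-fold lower number from compound 1 to compound 2 (0.01 log units; within the scatter). That exchange of cyclohexyl for propyl left the number within the scatter, so a ring and an open chain did not separate here. Within the data shown here, neither group is aromatic, however, and no measured compound carries an aromatic ring on this nitrogen, so this single step is a weak guide. Taking compound 2 at 7320 nM as the starting point, no change beyond the scatter is expected in this assay, though the uncertainty is wide. The estimated step is a 1.5-fold lower number from compound 2 to compound 3 (0.17 log units; within the scatter). For compound 3 the estimate is 5000 nM, with an expected range from 1500 nM to 15000 nM.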

Compound 3, half-maximal inhibitory concentration: 8610 nM
For compound 3 the middle estimate is 1.7-fold (0.24 log units) below the measured one; low and high end bracket the measured number.
By their numbers in this assay, from the lowest: compounds 2, 1 and 3 (each within the scatter of the next).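

In this assay, for the compounds shown here, this nitrogen now carries an aromatic ring for the first time, a case that the propyl and cyclohexyl compounds could not speak to. Putting 1-methyl-1H-pyrazol-4-yl in place of propyl gives a 1.2-fold higher number from compound 2 to compound 3 (0.07 log units; within the scatter) and putting it in place of cyclohexyl gives a 1.2-fold higher number from compound 1 to compound 3 (0.06 log units; within the scatter), so an open chain, a saturated ring and a five-membered aromatic ring with 2 hetero atoms all remain within the scatter of one another, even as the count of hydrogen-bond acceptors in the group goes from 0 to 2. Nothing measured here explains why these three groups do not separate.

The compounds shown leave open whether this position would respond to a group of another kind, such as a carboxylic acid, an amine carried on a longer chain or a plain phenyl ring. They also leave open whether the same indifference to the group on this nitrogen would hold if the chlorine or trifluoromethyl group at the other end of the molecule were replaced.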